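This account rests on a few compounds, and the source may have more. Where it says the series, first, only, none or still open, it means among the compounds named here.

Working notes on the series.

Compound 1 `O=C(/C=C/c1cccc(NC(=S)Nc2ccccc2)c1)C[C@@H]1OC[C@@H](O)[C@H](O)[C@H]1O` and compound 2 `Cc1ccc(S(=O)(=O)Nc2cccc(/C=C/C(=O)C[C@@H]3OC[C@@H](O)[C@H](O)[C@H]3O)c2)cc1` are built on one core; compound 3 `CC(=O)OC[C@H]1O[C@@H](CC(=O)/C=C/c2cccc(NS(=O)(=O)c3ccc(C)cc3)c2)[C@@H](OC(C)=O)[C@@H](OC(C)=O)[C@@H]1OC(C)=O` and compound 4 `CC(=O)OC[C@H]1O[C@@H](CC(=O)/C=C/c2cccc(NC(=S)Nc3ccccc3)c2)[C@@H](OC(C)=O)[C@@H](OC(C)=O)[C@@H]1OC(C)=O` are built on another. The difference between the two cores is not broken down here.

In an ADME assay on Vero cells (Chlorocebus sabaeus) for cytotoxicity, read by resazurin assay, with a stated time of 2 days (a lower number here means that less compound is tolerated, a higher number that more compound is tolerated), compound 2 gives 94700 nM. In this assay compound 1 gives 289000 nM. The change between these two is a group of 9 heavy atoms (7 carbon, 1 nitrogen, 1 sulfur; one six-membered aromatic ring of carbon only) in place of a group of 10 heavy atoms (7 carbon, 2 oxygen, 1 sulfur; one six-membered aromatic ring of carbon only), on a nitrogen on an aromatic ring, and it made a 3.1-fold higher number from compound 2 to compound 1 (0.48 log units; beyond the scatter). In this assay compound 3 gives 123000 nM; this value and that of compound 2 lie within the scatter of each other, while the value of compound 1 stands beyond the scatter above that of compound 3.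

Compound 4 is not yet measured. The change from compound 3 to compound 4 is a group of 9 heavy atoms (7 carbon, 1 nitrogen, 1 sulfur; one six-membered aromatic ring of carbon only) in place of a group of 10 heavy atoms (7 carbon, 2 oxygen, 1 sulfur; one six-membered aromatic ring of carbon only), on a nitrogen on an aromatic ring. Among the measured compounds shown here, the place of the change is described in the same words for both pairs, so this is the same change as the one from compound 2 to compound 1, now carried out on the other core. For the measured compounds named here, the expected step is a 2.8-fold higher number from compound 3 to compound 4 (0.45 log units; beyond the scatter) in this assay, and this expectation rests on the single earlier step of a 3.1-fold higher number from compound 2 to compound 1 (0.48 log units; beyond the scatter) from compound 2 to compound 1. Going by the values given here, with only one precedent on a different core the range must be kept wide. Compound 4 is estimated at 350000 nM in this assay, with the expected range running from 150000 nM to 800000 nM.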

Compound 4, half-maximal cytotoxic concentration: 65100 nM
Compound 4: middle estimate off by 5.4-fold (0.73 log units), on the high side; the whole stated range lies above it.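

In this assay, replacing the (4-methylphenyl)sulfonyl group on a nitrogen on an aromatic ring gives a 1.9-fold lower number from compound 3 to compound 4 (0.28 log units; within the scatter), a step within the scatter, whereas the same change on the other core gave a 3.1-fold higher number from compound 2 to compound 1 (0.48 log units; beyond the scatter). The change therefore does not carry over as a fixed step between the two cores in this series, and the two steps differ by more than their scatter allows: the same change on two cores in this assay, a 3.1-fold higher number (0.48 log units; beyond the scatter) from compound 2 to compound 1 and a 1.9-fold lower number (0.28 log units; within the scatter) from compound 3 to compound 4, 5.8-fold (0.76 log units) apart, beyond the scatter of two such steps This shows that, for these two matched pairs, the result of the change depends on the core it is made on, but it does not show which feature of the cores is responsible, and with a single pair on each core it gives no general rule, nor does it establish a real fall on the second core.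

The compounds shown leave open whether other groups on that nitrogen, such as an acetyl or a methylsulfonyl group, would also give different steps on the two cores. Also open, on these data alone, is which part of the difference between the two cores goes with this split, and whether the same split would appear in a read-out other than this assay.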